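A few compounds are considered here, and "the series" means these few. Any claim that something is new, unique, unknown or untested is made for them only; others in the source may bear on it.

Three analogues on a shared core are in hand. Compound 1 `C=CCOc1ccc(C(=O)Nc2cccc(C)n2)cc1` gives 31700 nM in an in vitro assay on HEK-tsA201 cells for antagonist activity at Neuronal acetylcholine receptor; alpha3/beta4 (Homo sapiens), read by fluorescence and calcium flux; a lower number here means a stronger inhibitor, a higher number a weaker inhibitor. Compound 2 `C=CCOc1ccc(C(=O)Nc2ccccn2)cc1` gives 61400 nM in this assay. Compound 3 `C=CCOc1ccc(C(=O)Nc2cccc(Br)n2)cc1` gives 65500 nM in this assay, the highest of the three numbers; the gaps are a 1.1-fold higher number from compound 2 to compound 3 (0.03 log units; within the scatter) and a 2.1-fold higher number from compound 1 to compound 3 (0.32 log units; beyond the scatter). Compound 4 `C=CCOc1ccc(C(=O)Nc2cccc(Cl)n2)cc1` differs from compound 3 by chloro in place of bromo on an aromatic carbon, next to the ring nitrogen and meta to a large group. Among the measured compounds shown here, no measured step swaps one halogen for another. The nearest bearing is a 1.1-fold higher number from compound 2 to compound 3 (0.03 log units; within the scatter), where hydrogen and bromo at this carbon give similar numbers, and a 2.1-fold higher number from compound 1 to compound 3 (0.32 log units; beyond the scatter), a modest step. For compound 4 the expected step is therefore a 1.2-fold lower number from compound 3 to compound 4 (0.08 log units; within the scatter). The estimate for compound 4 in this assay is 55000 nM, with a range from 20000 nM to 150000 nM.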

Compound 4, half-maximal inhibitory concentration: > 100000 nM
Compound 4: no number, only a limit; the forecaster's own chance of this, stated with the estimate: 15%; middle value at least 1.8-fold (0.25 log units) away from the limit.
By their numbers in this assay, from the lowest: compounds 1, 2 and 3 (each within the scatter of the next, the first and the last beyond it). At a limit, above all of these: compound 4.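

Compound 4 stands at a limit of the assay, not at a number: the limit of > 100000 nM in this assay, at which 1 of the 4 values shown sits. The floors an at least 1.5-fold higher number from compound 3 to compound 4 (0.18 log units; that floor lies within the scatter) and an at least 1.6-fold higher number from compound 2 to compound 4 (0.21 log units; that floor lies within the scatter) lie within the scatter, so chloro at this carbon cannot yet be separated from bromo or hydrogen. Only an at least 3.1-fold higher number from compound 1 to compound 4 (0.49 log units; beyond the scatter) lies beyond it, so both halogens now stand apart from methyl, while compound 2, with hydrogen, remains within the scatter of compound 1.

Going by these compounds, the true size of the change from bromo to chloro stays open. So does whether an amine, a methoxy group or a longer alkyl chain at this carbon would give a lower number than methyl.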